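This account rests on a few compounds, and the source may have more. Where it says the series, first, only, none or still open, it means among the compounds named here.

Compound 1, `O=c1c(Cc2coc3cccc(OCC4CCCCC4)c3c2=O)coc2ccccc12`, is the reference point of this small set. In a functional assay on NUGC-3 cells (Homo sapiens) for antiproliferative activity, read by XTT assay (a higher number here means a weaker inhibitor, a lower number a stronger inhibitor), compound 1 gives 3530 nM, the lowest of the two numbers recorded here; compound 3, `O=c1c(Cc2coc3cccc(OCc4ccccc4)c3c2=O)coc2ccccc12`, comes nearest with 7220 nM. Compound 2, `CC(C)CCOc1cccc2occ(Cc3coc4ccccc4c3=O)c(=O)c12`, is recorded only as a limit of the assay, > 10000 nM. The two steps with a measured number are a 2.0-fold higher number from compound 1 to compound 3 (0.31 log units; beyond the scatter) and an at least 2.8-fold higher number from compound 1 to compound 2 (0.45 log units; beyond the scatter), and the third pairing shows an at least 1.3-fold lower number from compound 2 to compound 3 (0.14 log units; that floor lies within the scatter). All three steps alter the group on a saturated chain carbon bound to an oxygen on an aromatic ring, and one of them rests on (the limit of > 10000 nM in this assay, at which 1 of the 3 values shown sits).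

Compound 4, `COc1ccc2c(=O)c(Cc3coc4cccc(OCC5CCCCC5)c4c3=O)coc2c1`, differs from compound 1 in another part of the core: methoxy in place of hydrogen on an aromatic carbon. Within the data shown here, none of the measured steps touches that position, so nothing recorded here speaks to the size or direction of the change. One therefore expects no step beyond the scatter, a 1.0-fold lower number from compound 1 to compound 4 (0.00 log units; within the scatter), with the wide uncertainty that an untested position deserves. The estimate for compound 4 in this assay is 3500 nM, with a range from 1200 nM to 10000 nM.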

Compound 4, half-maximal inhibitory concentration: 1440 nM
The estimate for compound 4 lay 2.4-fold (0.39 log units) above the measured number; low and high end bracket the measured number.
By their numbers in this assay, from the lowest: compound 4; then compound 1; then compound 3. At a limit, above all of these: compound 2.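

Until this point, every step in this assay had altered the group on the saturated chain carbon bound to an oxygen on an aromatic ring, while the other part of the core stayed the same. With methoxy in place of hydrogen on an aromatic carbon, the step is a 2.5-fold lower number from compound 1 to compound 4 (0.39 log units; beyond the scatter), so this position on a six-membered aromatic ring of carbon only, part of a fused or bridged system of two rings, is not silent: an entering group of 2 heavy atoms moves the number beyond the scatter and towards a stronger inhibitor, with the cyclohexyl group on the chain unchanged. Nothing shown here accounts for this change.

The compounds shown pair methoxy only with the cyclohexyl group, and whether it would lower the number in the same way alongside the isobutyl or phenyl group remains open. Also open, as far as these compounds go, is how a hydroxyl group, a fluorine atom or an amine on this same aromatic carbon would compare with methoxy.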